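Nitro to tert-butoxy on compound 3

The compounds below may be only part of what the source reports. "The series", "measured", "known", "first", "only" and "open" are said of these compounds alone.

Values in a functional assay on A549 cells (Homo sapiens) for inhibition, read by MTT assay, with a stated time of 72 h; on this read-out lower numbers stand for stronger inhibition and higher numbers for weaker inhibition:
compound 1 `O=[N+]([O-])c1ccc(-c2nnc(SCCCN3CCN(c4nc5ccccc5o4)CC3)o2)cc1`: 90800 nM
compound 2 `Oc1ccc(-c2nnc(SCCCN3CCN(c4nc5ccccc5o4)CC3)o2)cc1`: 181000 nM
compound 3 `O=[N+]([O-])c1ccc(-c2nnc(SCCCN3CCN(c4nc5ccccc5s4)CC3)o2)cc1`: 96600 nM

Compound 3, at 96600 nM, lies within the scatter of both compound 1 and compound 2, so the three values form a single group. Compound 4 `CC(C)(C)Oc1ccc(-c2nnc(SCCCN3CCN(c4nc5ccccc5s4)CC3)o2)cc1` has tert-butoxy in place of nitro on an aromatic carbon, para to a large group: tert-butoxy in place of nitro on an aromatic carbon.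

Within the data shown here, two measured steps bear on this. The closest is a 2.0-fold higher number from compound 1 to compound 2 (0.30 log units; within the scatter), which changes the same nitro group, though to hydroxy and with the other bicyclic substituent on the amine nitrogen. The second, a 1.1-fold higher number from compound 1 to compound 3 (0.03 log units; within the scatter), exchanges 1,3-benzoxazol-2-yl for 1,3-benzothiazol-2-yl and suggests that the nitro comparison carries over to compound 3. Both steps lie within the scatter. Among the measured compounds shown here, no measured compound carries tert-butoxy, so the expectation is an extrapolation, with no step beyond the scatter and no favoured direction. The expected change is a 1.1-fold higher number from compound 3 to compound 4 (0.06 log units; within the scatter).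

For compound 4 the estimated value is 110000 nM, with an expected range of 45000 nM to 220000 nM.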

Compound 4, half-maximal inhibitory concentration: 71600 nM
The estimate for compound 4 lay 1.5-fold (0.19 log units) above the measured number; the measured number falls inside the stated range.
By their numbers in this assay, from the lowest: compounds 4, 1, 3 and 2 (each within the scatter of the next, the first and the last beyond it).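

In this assay, tert-butoxy in place of nitro on the aromatic carbon para to a large group gives a 1.3-fold lower number from compound 3 to compound 4 (0.13 log units; within the scatter) and so stays within the scatter. The earlier step at this position, a 2.0-fold higher number from compound 1 to compound 2 (0.30 log units; within the scatter) with 1,3-benzoxazol-2-yl on the amine nitrogen, also lies within the scatter, and the new step extends that reading to a compound with 1,3-benzothiazol-2-yl in that place and to a group of 5 heavy atoms with no nitrogen. No supporting evidence bears on this result.

From the compounds shown here alone, whether an amine or a carboxylic acid at this position would move the number beyond the scatter remains open. Also open, going by these compounds, is how a shorter or longer chain on the sulfur of the shared core would read.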